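The source may hold more compounds than are shown below. What is called first, only, known or untested is meant among the compounds shown, and "the series" means these compounds.

Compound 1 `Cc1nc(-c2ccc(C(F)(F)F)cc2)sc1CNc1ccc(C(=O)O)cc1`: in a functional assay on CHO cells for agonist activity at Free fatty acid receptor 1 (Homo sapiens) (on this read-out higher numbers stand for an effect only at larger amounts of compound and lower numbers for an effect already at smaller amounts), compound 1 gives < 10000 nM, which is a limit of the assay rather than a number.
Compound 2 `Cc1nc(-c2ccc(C(F)(F)F)cc2)sc1CNc1ccc(CC(=O)O)cc1`: in this assay compound 2 gives < 10000 nM, again a limit and not a number.
Compound 3 `O=C(O)CCCc1ccc(NCc2cccc(Oc3ccccc3)c2)cc1`: in this assay compound 3 gives 1120 nM.

Compound 3 is therefore the only one of the three with a measured number; the other two sit at the limit of < 10000 nM in this assay, at which 2 of the 3 values shown sit, so compound 3 cannot be ranked against them. Going by the values given here, the one step between measured compounds that differ in a single place, a step that the two limits leave unreadable from compound 1 to compound 2, is the change of carboxymethyl in place of carboxy on an aromatic carbon, and the two limits leave its size unreadable.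

Compound 4 `CC(CC(=O)O)c1ccc(NCc2cccc(Oc3ccccc3)c2)cc1` differs from compound 3 by 1-(carboxymethyl)ethyl in place of 3-carboxypropyl on an aromatic carbon. Among the compounds with values here, no measured step bears directly on this rearrangement of the acid-bearing chain: the only step available, from compound 1 to compound 2, concerns a different pair of groups and gives no readable size. With nothing to point toward a shift in either direction, the step from compound 3 to compound 4 is expected to stay within the usual scatter, at about a 1.3-fold higher number from compound 3 to compound 4 (0.10 log units; within the scatter). Compound 4 is accordingly estimated at 1400 nM in this assay, with a range from 400 nM to 5000 nM.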

Compound 4, half-maximal effective concentration: 126 nM
Compound 4: middle estimate off by 11-fold (1.05 log units), on the high side, and the stated range ends above it.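

In this assay, the acid-bearing chain on the aromatic carbon para to a large group proves to be a sensitive point: an 8.9-fold lower number from compound 3 to compound 4 (0.95 log units; beyond the scatter) accompanies the switch from 3-carboxypropyl to 1-(carboxymethyl)ethyl. Going by these compounds alone, the two groups have the same atoms and the same counts of donors, acceptors and double bonds, so this step comes from how the atoms are joined, not from any atom gained or lost, and it is the first readable size for a change in the acid-bearing group, as the earlier step between the two limits could not be read. Nothing measured here explains why this rearrangement moves the number as far as it does.

The compounds shown leave open how 2-carboxyethyl, which has no methyl branch, or 1-(carboxymethyl)propyl, which has an ethyl branch, would read at this place, and so whether the step follows the branch itself or the shorter path to the carboxylic acid. They also leave open whether 1-(carboxymethyl)ethyl would give a similar step on the core of compound 1.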